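Cyano in place of methylsulfonyl on compound 2

The source may report more compounds than this note shows. Statements on the series, on what has been measured and on what is new or still open speak of the compounds shown alone.

In a functional assay on isolated protein for agonist activity at Glucose-dependent insulinotropic receptor (Homo sapiens), read by HTRF and cAMP accumulation (a lower number here means a smaller maximal response, a higher number a larger maximal response), compound 2 `CC(C)(C)OC(=O)N1CCC(O[C@H]2CC[C@H](Oc3cnc(S(C)(=O)=O)cn3)CC2)CC1` gives 110%, the lowest of the two numbers measured, while compound 1 `CC(C)(C)OC(=O)N1CCC(O[C@H]2CC[C@H](Oc3ccc(S(C)(=O)=O)cc3)CC2)CC1` gives 115%. The step of a number 5 percentage points lower from compound 1 to compound 2 (within the scatter) is the only one measured, and it concerns the ring rather than the group exchanged next. Compound 3 `CC(C)(C)OC(=O)N1CCC(O[C@H]2CC[C@H](Oc3cnc(C#N)cn3)CC2)CC1` differs from compound 2 by cyano in place of methylsulfonyl on an aromatic carbon. Among the compounds with values here, no measured step exchanges this group, so the expectation rests on both measured values sitting near full response. Compound 3 is expected to stay there, with a step of a number 2 percentage points lower from compound 2 to compound 3 (within the scatter) not beyond the scatter. The estimate for compound 3 is 108%, between 95% and 120%.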

Compound 3, largest response reached (Emax), in percent of the reference or control that the assay uses: 110%
Compound 3: the middle estimate sits 2 percentage points below what was measured; low and high end bracket the measured number.
By their numbers in this assay, from the lowest: compounds 2, 3 and 1 (each within the scatter of the next).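

In this assay, cyano in place of methylsulfonyl on this aromatic carbon gives no change at the digits printed from compound 2 to compound 3 (within the scatter), so at this position of the 5-substituted pyrazin-2-yl group the maximal response does not depend on methylsulfonyl. Changing both places at once, 5-cyanopyrazin-2-yl in place of 4-(methylsulfonyl)phenyl, gives a number 5 percentage points lower from compound 1 to compound 3 (within the scatter), so the maximal response also holds across this larger exchange. Nothing available explains why the response holds with either group. Still open, as far as these compounds go, is whether an amine or a carboxylic acid at this position would keep the response, and whether cyano would do the same on the phenyl ring of compound 1.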